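Alkyl growth on the shared core: methyl to ethyl

The source may hold more compounds than are shown below. What is called first, only, known or untested is meant among the compounds shown, and "the series" means these compounds.

Measured so far in a functional assay on HeLa cells (Homo sapiens) for antiproliferative activity, read by cell counting, with a stated time of 5 days; on this read-out lower numbers stand for stronger inhibition and higher numbers for weaker inhibition:
compound 1 `CCc1c(-c2ccc(OC)cc2)noc1-c1ccc(OC)cc1`: > 100000 nM
compound 2 `Oc1ccc(-c2cc(-c3ccc(O)cc3)on2)cc1`: 6000 nM
compound 3 `Cc1c(-c2ccc(O)cc2)noc1-c1ccc(O)cc1`: 15000 nM

The value of compound 1 is a limit of this assay, not a number (the limit of > 100000 nM in this assay, at which 1 of the 3 values shown sits). Among the two numbers, compound 3 stands highest; its nearest neighbour is compound 2, the step being a 2.5-fold higher number from compound 2 to compound 3 (0.40 log units; beyond the scatter). Compound 4 `CCc1c(-c2ccc(O)cc2)noc1-c1ccc(O)cc1` differs from compound 3 by methyl in place of hydrogen on a saturated chain carbon bound to an aromatic carbon; read one bond further out, methyl becomes ethyl. Within the data shown here, the only measured step that bears on it adds a carbon at a neighbouring place, and it was modest. A further modest step in this assay, toward a higher number or none beyond the scatter, is therefore expected, i.e. a 1.5-fold higher number from compound 3 to compound 4 (0.17 log units; within the scatter) is the estimate. Compound 4 is expected at 22000 nM, range 8000 nM to 60000 nM.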

Compound 4, half-maximal inhibitory concentration: 16000 nM
Compound 4: middle estimate off by 1.4-fold (0.14 log units), on the high side; the measured number falls inside the stated range.
By their numbers in this assay, from the lowest: compound 2; then compounds 3 and 4 (each within the scatter of the next). At a limit, above all of these: compound 1.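

In this assay, the methyl and ethyl versions of the shared core cannot be told apart, with a 1.1-fold higher number from compound 3 to compound 4 (0.03 log units; within the scatter). Measured against the core without either group, ethyl gives a 2.7-fold higher number from compound 2 to compound 4 (0.43 log units; beyond the scatter), in line with the methyl step, a 2.5-fold higher number from compound 2 to compound 3 (0.40 log units; beyond the scatter), so the first carbon carries the step from hydrogen and the second adds nothing beyond the scatter. Nothing measured here accounts for this flat step.

Still open, going by these compounds, is how far the position tolerates growth: whether a longer chain such as propyl stays within the scatter of compound 3. Also open, on these data alone, is how an amine at this place would read.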